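Shortening the phenoxy side chain of EP3 agonists

The source may hold more compounds than are shown below. What is called first, only, known or untested is meant among the compounds shown, and "the series" means these compounds.

Four compounds built on one shared core carrying a carboxylic acid on a thiazole ring are compared here. Compound 2 `O=C(O)c1csc([C@H]2CC[C@@H]3[C@@H](/C=C/CCCOc4ccccc4)[C@H](O)C[C@@H]3O2)n1` carries a 2-phenoxyethyl group on a saturated chain carbon bound to a double-bonded chain carbon, and in a functional assay on CHO cells for agonist activity at prostaglandin E2 receptor EP3 subtype (Homo sapiens), read by fluorescence and calcium flux (a lower number here means that less compound is needed, a higher number that more compound is needed for the effect), compound 2 gives 360 nM. Compound 1 `O=C(O)c1csc([C@H]2CC[C@@H]3[C@@H](/C=C/COc4ccccc4)[C@H](O)C[C@@H]3O2)n1` differs from it only by phenoxy in place of 2-phenoxyethyl on a saturated chain carbon bound to a double-bonded chain carbon, and in this assay compound 1 gives 7600 nM. That change made a large step: a 21-fold higher number from compound 2 to compound 1 (1.32 log units; beyond the scatter).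

Compound 3 `O=C(O)c1csc([C@H]2CC[C@@H]3[C@@H](CCCCCOc4ccccc4)[C@H](O)C[C@@H]3O2)n1` has a fully saturated side chain ending in the same phenoxy group; the difference between its core and that of compound 2 is not broken down here, and in this assay the result for compound 3 is "not determined" (no result reported). Compound 4 `O=C(O)c1csc([C@H]2CC[C@@H]3[C@@H](CCCOc4ccccc4)[C@H](O)C[C@@H]3O2)n1` differs from compound 3 by phenoxy in place of 2-phenoxyethyl on a saturated chain carbon, three bonds along the chain from a saturated ring carbon. Among the compounds with values here, this is the same kind of change as the one from compound 2 to compound 1, but the place is not identical: in compound 1 it sits on a saturated chain carbon bound to a double-bonded chain carbon, in compound 4 on a saturated chain carbon three bonds along the chain from a saturated ring carbon.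

Because the step of a 21-fold higher number from compound 2 to compound 1 (1.32 log units; beyond the scatter) was large and compound 1 gives 7600 nM, compound 4 is expected to need a similarly high concentration. The estimate for compound 4 in this assay is 9000 nM, with a range from 2000 nM to 40000 nM, resting on a single comparison and so uncertain.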

Compound 4, half-maximal effective concentration: 5800 nM
Compound 4: the middle estimate sits 1.6-fold (0.19 log units) above what was measured, and the stated range covers the measured number.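

In this assay, within the data shown here, compound 4 gives 5800 nM but compound 3 has no number there, so no step from compound 3 to compound 4 can be read. The compounds shown leave open whether replacing 2-phenoxyethyl with phenoxy on the fully saturated chain shifts the number as much as it does between compound 2 and compound 1. No supporting data are available to explain the result for compound 4.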